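One Aryl Swap on a Shared Core

The source may report more compounds than this note shows. Statements on the series, on what has been measured and on what is new or still open speak of the compounds shown alone.

Compound 1 `COc1cc(-c2cc(/C=C/C(=O)c3ccc(N)cc3)[nH]n2)cc(OC)c1OC` was tested in a functional assay on IGROV-1 cells (Homo sapiens) for cytotoxicity, read by sulforhodamine B assay, with a stated time of 48 h, tested at 100 uM (on this read-out higher numbers stand for a weaker effect at the one concentration tested and lower numbers for a stronger effect), where compound 1 gives -49%. Among the compounds with values here, that is the highest of the two numbers known, hence the weaker effect: compound 2 `COc1ccc(-c2cc(/C=C/C(=O)c3ccc(OC)c(OC)c3)[nH]n2)cc1` gives -84%, a number beyond the usual scatter below that of compound 1. Compound 3 `COc1cc(-c2cc(/C=C/C(=O)c3ccc(Cl)c(Cl)c3)[nH]n2)cc(OC)c1OC` is compound 1 with one change, (3,4-dichlorophenyl in place of 4-aminophenyl on a carbonyl carbon). Within the data shown here, no measured pair shows this change, so the direction is uncertain. A modest move toward a stronger effect is expected, of about a number 13 percentage points lower from compound 1 to compound 3 (beyond the scatter), which may still sit within the scatter. Compound 3 is expected at -62%, within -100% to -15%.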

Compound 3, a percentage reported as activity, at one concentration (the size of the read-out at that concentration, not a potency): 9%
Estimate against measurement, compound 3: 71 percentage points below; measured number above the stated range.
By their numbers in this assay, from the lowest: compound 2; then compound 1; then compound 3.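

The aryl group on this carbonyl carbon strongly shapes the result: in this assay, placing 3,4-dichlorophenyl where 4-aminophenyl stood gives a number 58 percentage points higher from compound 1 to compound 3 (beyond the scatter). Within the data shown here, this is a large move toward a weaker effect, and it is the first comparison of compounds that differ in this one place. The data shown offer no measured explanation for the change.

Still open, on these data alone, is whether the loss follows from removing the amine or from adding the two chlorines. A hydroxyl or dimethylamino group in the amine's place could help separate these two possibilities.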